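Moving a fluorine around the benzoyl ring of a DP2 antagonist

The source may hold more compounds than are shown below. What is called first, only, known or untested is meant among the compounds shown, and "the series" means these compounds.

Measured compounds:
compound 1, `O=C(O)CCC(=O)N(C1CC1)C1c2ccccc2N(C(=O)OCc2ccccc2)C2CCC21`, 210 nM
compound 2, `O=C(O)COC(=O)N(C1CC1)[C@H]1c2ccccc2N(C(=O)c2cccc(F)c2)[C@H]2CC[C@H]21`, 0.8 nM
compound 3, `O=C(O)CCC(=O)N(C1CC1)[C@H]1c2ccccc2N(C(=O)c2ccc(F)cc2)[C@H]2CC[C@H]21`, 20 nM

In a functional assay on cells for antagonist activity at prostaglandin D2 receptor 2 (Homo sapiens), read by ELISA, chemiluminescence and cAMP accumulation, with stated times of 10 min and 60 min (a higher number here means a weaker inhibitor, a lower number a stronger inhibitor), compound 2 gives the lowest number of the three; compound 3 sits a good way above it and compound 1 further still, both gaps clearly beyond the scatter. Compound 4, `O=C(O)COC(=O)N(C1CC1)[C@H]1c2ccccc2N(C(=O)c2ccc(F)cc2)[C@H]2CC[C@H]21`, differs from compound 2 in one place: 4-fluorophenyl in place of 3-fluorophenyl on a carbonyl carbon. Among the measured compounds shown here, no measured pair shows this change alone, since compound 3 also carries a different acid chain, so its size is open. A modest weakening, if any, is expected, a 2.5-fold higher number from compound 2 to compound 4 (0.40 log units; beyond the scatter), and compound 4 is estimated at 2 nM, within a range from 0.6 nM to 8 nM.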

Compound 4, half-maximal inhibitory concentration: 2 nM
Compound 4: the middle estimate sits on the measured number at the digits printed; the range from low to high includes it.
By their numbers in this assay, from the lowest: compound 2; then compound 4; then compound 3; then compound 1.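

In this assay, 4-fluorophenyl in place of 3-fluorophenyl on a carbonyl carbon gives a 2.5-fold higher number from compound 2 to compound 4 (0.40 log units; beyond the scatter), so the fluorine's place on this ring matters on its own, though modestly. Carboxymethoxy in place of 2-carboxyethyl on a carbonyl carbon gives a 10-fold lower number from compound 3 to compound 4 (1.00 log units; beyond the scatter), isolating a change of the acid chain that the earlier compounds could not separate from the fluorine change. Nothing shown here explains either step. Still open, as far as these compounds go, is how a chlorophenyl or an unsubstituted phenyl would fare on that carbonyl, and how a longer carboxylic acid chain would compare with carboxymethoxy.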